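Fluoro in place of hydrogen on the core of compound 2

The source may hold more compounds than are shown below. What is called first, only, known or untested is meant among the compounds shown, and "the series" means these compounds.

Measured so far:
compound 1 `CCOC(=O)c1c(-c2cccc(OCC)c2)[nH]c2cc(OC)ccc2c1=O`: > 21500 nM
compound 2 `CCOC(=O)c1c(-c2cccc(Br)c2)[nH]c2cc(OC)ccc2c1=O`: > 21500 nM

In an ADME assay on HepG2 cells (Homo sapiens) for cytotoxicity, read by luminescence, with a stated time of 72 h (a higher number here means that more compound is needed for the effect, a lower number that less compound is needed), compound 1 gives only a limit, > 21500 nM. Compound 2 also gives only a limit, > 21500 nM. This is the limit of > 21500 nM in this assay, at which 2 of the 2 values shown sit, so the step that the two limits leave unreadable from compound 1 to compound 2 cannot be read. Compound 3 `CCOC(=O)c1c(-c2cccc(Br)c2)[nH]c2cc(OC)c(F)cc2c1=O` differs from compound 2 by fluoro in place of hydrogen on an aromatic carbon. No measured step bears on this change, and the one step shown is unreadable. Compound 3 is therefore expected to stay near the limit, estimated at 30000 nM with a range of 12000 nM to 80000 nM. This estimate means a step that the limit leaves unreadable from compound 2 to compound 3 that is expected to lie within the scatter.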

Compound 3, half-maximal effective concentration: > 21500 nM
Compound 3: a limit, no number (the forecaster's own chance of this, stated with the estimate: 75%); the middle value lies beyond the limit too.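

No step can be read from compound 2 to compound 3, since both give only a limit: the limit of > 21500 nM in this assay, at which 3 of the 3 values shown sit.

The compounds shown leave open whether bromo in place of ethoxy or fluoro in place of hydrogen changes the read-out in this assay at all.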